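Aryl amide variation on the shared core

A few compounds are considered here, and "the series" means these few. Any claim that something is new, unique, unknown or untested is made for them only; others in the source may bear on it.

Measured so far:
compound 1 `CN(C)C(=O)c1cc2cnc(Nc3ccc(NC(=O)C4(C(=O)Nc5ccc(F)cc5)CC4)cc3)nc2n1C1CCCC1` gives 98%
compound 2 `CN(C)C(=O)c1cc2cnc(Nc3ccc(NC(=O)C4(C(=O)Nc5cccc(O)c5)CC4)cc3)nc2n1C1CCCC1` gives 75.7%

In a functional assay on SiHa cells (Homo sapiens) for inhibition, read by CCK-8 assay, with a stated time of 72 h, tested at 10 uM (a higher number here means more inhibition of growth at the concentration tested, a lower number less inhibition of growth), compound 1 stands highest of the two numbers, with compound 2 below it. Among the compounds with values here, the one measured step, a number 22.3 percentage points lower from compound 1 to compound 2 (beyond the scatter), is the only one bearing on compound 3 `CN(C)C(=O)c1cc2cnc(Nc3ccc(NC(=O)C4(C(=O)Nc5cccc(Br)c5)CC4)cc3)nc2n1C1CCCC1`, which carries 3-bromophenyl in place of 4-fluorophenyl on an amide-type nitrogen. Within the data shown here, that step shows a modest loss when the aryl group on the amide-type nitrogen is changed, but a bromophenyl at this place has no precedent here. A step of a number 10 percentage points lower from compound 1 to compound 3 (within the scatter) is expected, a small decrease that may stay within the scatter. Compound 3 is therefore estimated at 88%, with a range from 70% to 99%.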

Compound 3, percent growth inhibition at one concentration: 92.5%
Compound 3: the middle estimate sits 4.5 percentage points below what was measured; the range from low to high includes it.
By their numbers in this assay, from the lowest: compound 2; then compounds 3 and 1 (each within the scatter of the next).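

In this assay, the place on the amide-type nitrogen accepts 3-bromophenyl as well as 4-fluorophenyl: a number 5.5 percentage points lower from compound 1 to compound 3 (within the scatter) shows that the loss seen with 3-hydroxyphenyl does not extend to every replacement. With only the group on the aromatic carbon changed, a number 16.8 percentage points higher from compound 2 to compound 3 (beyond the scatter) shows that bromo and hydroxy are not interchangeable here. No measurement at hand gives a reason for this difference.

Because 4-fluorophenyl and 3-bromophenyl differ in both halogen and ring position, the two changes remain unseparated. On these data alone, how an amine or a carboxylic acid on this aromatic carbon would compare also remains open.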